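The source may report more compounds than this note shows. Statements on the series, on what has been measured and on what is new or still open speak of the compounds shown alone.

Working notes on the series.

Compound 2 `COc1cc(/C=C/C(=O)Nc2ccccc2)ccc1OCCCCCCN(C)C` is the reference for this step. For the measured compounds named here, in a physicochemical assay for lipophilicity, using the shake flask method, measured as octanol-water partition, at pH 7.4 (a higher number here means a more lipophilic compound, a lower number a more polar compound), compound 2 gives 1.69, the higher of the two numbers so far, with compound 1 `COc1cc(/C=C/C(=O)Nc2ccccc2)ccc1OCCCCN1CCCC1` the nearest neighbour, where in this assay compound 1 gives 1.6. Going by the values given here, the single measured step, a number 0.09 log units higher from compound 1 to compound 2 (within the scatter), came with 2-(dimethylamino)ethyl in place of pyrrolidin-1-yl on a saturated chain carbon, four bonds along the chain from an oxygen on an aromatic ring, and stays within the scatter.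

Compound 3 `CCN(CC)CCCCCCCCCCOc1ccc(/C=C/C(=O)Nc2ccccc2)cc1OC` is not yet measured. Its change from compound 2 is 4-(diethylamino)butyl in place of dimethylamino on a saturated chain carbon, six bonds along the chain from an oxygen on an aromatic ring. Among the compounds with values here, the only step available bears on it loosely: the step from compound 1 to compound 2 swapped groups of equal heavy-atom count and moved the number very little, whereas the change to compound 3 brings in six more heavy atoms on the chain with no change in donors, acceptors or charge. Within the data shown here, no measured step covers a growth of that size, so the expectation leans on the change itself rather than on any precedent. In this assay compound 3 is expected to rise by a number 1.81 log units higher from compound 2 to compound 3 (beyond the scatter) relative to compound 2. The estimate for compound 3 is therefore 3.5, with a range from 2.5 to 4.5.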

Compound 3, partition coefficient: 1.83
The estimate for compound 3 lay 1.67 log units above the measured number, and the stated range ends above it.
By their numbers in this assay, from the lowest: compounds 1, 2 and 3 (each within the scatter of the next).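

In this assay, 4-(diethylamino)butyl in place of dimethylamino on a saturated chain carbon, six bonds along the chain from an oxygen on an aromatic ring, gives a number 0.14 log units higher from compound 2 to compound 3 (within the scatter). For the compounds shown here, this is the first measured change at this position that alters the size of the group, from 3 heavy atoms to 9, all of the added atoms being carbon, and the printed step still does not separate the two compounds. Read from the other end of the series, 6-(diethylamino)hexyl in place of pyrrolidin-1-yl on a saturated chain carbon, four bonds along the chain from an oxygen on an aromatic ring, gives a number 0.23 log units higher from compound 1 to compound 3 (within the scatter), so even the widest pair shown here stays unresolved in this assay.

Open, going by these compounds, is whether that holds for a chain ending in something other than an amine, such as a hydroxyl group or a carboxylic acid, or for a longer chain than any of these three. Why so large a change in the group leaves the number within the scatter also stays open, and no measurement shown here bears on this result.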